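Adding a nitro group to compound 3

The source may hold more compounds than are shown below. What is called first, only, known or untested is meant among the compounds shown, and "the series" means these compounds.

Compound 1 `O=c1cc(Cc2c(F)cccc2F)nc(SCc2ccccc2)[nH]1` gives > 73000 nM
Compound 2 `O=c1cc(Cc2c(F)cccc2F)nc(SCc2c(F)cccc2F)[nH]1` gives > 66000 nM
Compound 3 `Cc1c(Cc2c(F)cccc2F)nc(SCc2ccccc2)[nH]c1=O` gives > 70000 nM

These results come from an ADME assay on MT4 cells (Homo sapiens) for cytotoxicity, read by MTT assay; a lower number here means that less compound is tolerated, a higher number that more compound is tolerated. Compound 3 gives only a limit, > 70000 nM, and not a number. The other two results are limits as well, so none of the three compounds can be ranked against the others.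

Compound 4 `Cc1c(Cc2c(F)cccc2F)nc(SCc2ccc([N+](=O)[O-])cc2)[nH]c1=O` differs from compound 3 by having nitro in place of hydrogen on an aromatic carbon, para to a large group, so that phenyl becomes 4-nitrophenyl: nitro in place of hydrogen on an aromatic carbon.

Within the data shown here, two measured steps bear on this change. The closer one also alters that phenyl: a step that the two limits leave unreadable from compound 1 to compound 2. The other alters the shared core: a step that the two limits leave unreadable from compound 1 to compound 3. Neither has a readable size, so they give only weak guidance. Compound 2 keeps a limit, > 66000 nM, even with its altered phenyl, so no clear change is expected here.

The expected change is no larger than the scatter: an at least 1.1-fold lower number from compound 3 to compound 4 (0.06 log units; that floor lies within the scatter). For compound 4 the estimated value is 60000 nM, with an expected range from 25000 nM to 80000 nM.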

Compound 4, half-maximal cytotoxic concentration: > 37000 nM
Compound 4 ended at the assay's limit; the forecaster's own chance of this, stated with the estimate: 75%; the middle value lies beyond the limit too.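

Compound 3 and compound 4 both give only limits and not numbers, and the step between them cannot be read. The compounds shown leave open whether nitro in place of hydrogen on an aromatic carbon shifts the result in this assay at all.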